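Replacing 4-fluorophenyl with 2-hydroxyethyl on an amine nitrogen

The source may report more compounds than this note shows. Statements on the series, on what has been measured and on what is new or still open speak of the compounds shown alone.

Compound 1 `Nc1nn2c(O)cc(CCl)nc2c1[N+](=O)[O-]`: > 50 ug/mL (a limit of the assay, not a number)
Compound 2 `Nc1nn2c(O)cc(CNNc3ccc(F)cc3)nc2c1[N+](=O)[O-]`: 41.4 ug/mL

Both results come from a functional assay on L929 cells (Mus musculus) for inhibition; a lower number here means a stronger inhibitor of growth, a higher number a weaker inhibitor of growth. Compound 1 is reported only as a limit, > 50 ug/mL. Among the compounds with values here, compound 2 gives 41.4 ug/mL, the only true number so far, so its standing cannot be expressed as a measured gap to another compound.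

The next compound to be tested is compound 3 `Nc1nn2c(O)cc(CNNCCO)nc2c1[N+](=O)[O-]`. It carries 2-hydroxyethyl in place of 4-fluorophenyl on an amine nitrogen, and the change counts as 2-hydroxyethyl in place of 4-fluorophenyl on an amine nitrogen. Within the data shown here, no measured pair of compounds shows what a change at this place does, so any expectation must rest on compound 2 at 41.4 ug/mL alone. A small move toward weaker inhibition of growth is expected, and the assay may report only a limit. The expected size is a 1.4-fold higher number from compound 2 to compound 3 (0.16 log units; within the scatter), an estimate that carries wide uncertainty. For compound 3 the estimated value in this assay is 60 ug/mL, with an expected range from 30 ug/mL to 120 ug/mL.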

Compound 3, concentration for 50% growth inhibition: > 50 ug/mL
Compound 3 was reported as a limit (the forecaster's own chance of this, stated with the estimate: 55%); the middle value does not contradict the limit.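

In this assay, within the data shown here, the change of 4-fluorophenyl to 2-hydroxyethyl on an amine nitrogen gives the first step that can be read at this position: an at least 1.2-fold higher number from compound 2 to compound 3 (0.08 log units; that floor lies within the scatter). That floor does not separate compound 3 from compound 2, and the true size of the step could be small or much larger. The reading stops at a floor because compound 3 gives only a limit of the assay, not a number: the limit of > 50 ug/mL in this assay, at which 2 of the 3 values shown sit.

The step between compound 1 and compound 3 cannot be read, as both results are limits. From the compounds shown here alone, it also remains open whether the aromatic ring or the fluorine of compound 2 goes with its measurable value, and a plain phenyl on the same amine nitrogen, or a longer chain or a terminal amine in place of 2-hydroxyethyl, would bear on that question.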